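The source may report more compounds than this note shows. Statements on the series, on what has been measured and on what is new or still open speak of the compounds shown alone.

Measured compounds:
- compound 1 `CC1=NN(C(=O)c2ccc([N+](=O)[O-])cc2)C(c2ccccc2O)C1` — 36600 nM
- compound 2 `CC1=NN(C(=O)c2ccc(C)cc2)C(c2ccccc2O)C1` — 40600 nM
- compound 3 `CC1=NN(C(=O)CCl)C(c2cc(Br)ccc2O)C1` — 8890 nM

All three share one core and were tested in a functional assay on PC-3 cells (Homo sapiens) for cytotoxicity, read by MTT assay, with a stated time of 48 h; a lower number here means a stronger inhibitor, a higher number a weaker inhibitor. For the measured compounds named here, compound 1 gives 36600 nM and compound 2 gives 40600 nM; the only single-point step among them, a 1.1-fold higher number from compound 1 to compound 2 (0.05 log units; within the scatter), changes nothing beyond the scatter. Compound 3 gives 8890 nM, the lowest of the three numbers, and its gap to each of the other two lies beyond the usual scatter.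

Compound 4 `CC1=NN(C(=O)COc2ccc(Cl)cc2)C(c2cc(Br)ccc2O)C1` is not yet measured. It differs from compound 3 in one place: 4-chlorophenoxy in place of chloro on a saturated chain carbon bound to a carbonyl carbon. Going by the values given here, no measured step touches this part of the molecule; the one step in hand, a 1.1-fold higher number from compound 1 to compound 2 (0.05 log units; within the scatter), sits on an aromatic ring elsewhere and was within the scatter, so it gives little guidance. With the replacement at the chain carbon next to the carbonyl, a moderate shift in this assay is expected, most likely toward a higher number, though a result within the scatter of compound 3 cannot be excluded. The expected step is a 2.2-fold higher number from compound 3 to compound 4 (0.35 log units; beyond the scatter). Compound 4 is therefore estimated at 20000 nM, within a range of 6000 nM to 70000 nM.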

Compound 4, half-maximal inhibitory concentration: 49000 nM
Compound 4: the middle estimate sits 2.5-fold (0.39 log units) below what was measured; low and high end bracket the measured number.
By their numbers in this assay, from the lowest: compound 3; then compounds 1, 2 and 4 (each within the scatter of the next).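

In this assay the saturated chain carbon bound to a carbonyl carbon proves to be a place where a change registers: 4-chlorophenoxy in place of chloro gives a clear shift toward a weaker inhibitor (a 5.5-fold higher number from compound 3 to compound 4 (0.74 log units; beyond the scatter)). For the compounds shown here, the only earlier step sat on an aromatic carbon and stayed within the scatter, so this is the first single change in the set that moves the number beyond it, and it does so while adding one six-membered aromatic ring and one hydrogen-bond acceptor. Nothing measured here accounts for the shift, so it stands as an observation without an explanation.

On these data alone, with a single replacement at this carbon, it remains open whether the loss follows from the phenoxy ring, from its chlorine or from the linking oxygen, and an unsubstituted phenoxy group would help separate these. As far as these compounds go, it is also open how an amine such as dimethylamino or a small methoxy group would behave at this carbon, and whether either would stay close to compound 3 or fall nearer compound 4.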